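Cyclopropylmethoxy in place of difluoroethoxy on the core of compound 1

The source may report more compounds than this note shows. Statements on the series, on what has been measured and on what is new or still open speak of the compounds shown alone.

Going by the values given here, compound 1 `O=C(O)Cn1nc(Cc2nc3cc(Cl)c(OCC(F)F)cc3[nH]2)c2ccccc2c1=O` gives 1.2 L/kg in an ADME assay on the whole organism (Mus musculus, strain CD1) for pharmacokinetics, read by LC-MS, with a stated time of 24 h, at a dose of 1 mg/kg by the intravenous route (a higher number here means that more of the compound sits outside the plasma, a lower number that more of the compound stays in the plasma), the highest of the three numbers measured so far. Compound 2 `O=C(O)Cc1nn(Cc2cn3cc(OCC4CC4)c(Cl)cc3n2)c2ccccc2c1=O` gives 0.79 L/kg in this assay, within the scatter of compound 1, and compound 3 `C[C@H](C(=O)O)c1nn(Cc2cn3cc(OCC4CC4)c(Cl)cc3n2)c2ccccc2c1=O` gives 0.56 L/kg, beyond it. Among the compounds with values here, the single measured step, a 1.4-fold lower number from compound 2 to compound 3 (0.15 log units; within the scatter), concerns a different group on a different core. Compound 4 `O=C(O)Cn1nc(Cc2nc3cc(Cl)c(OCC4CC4)cc3[nH]2)c2ccccc2c1=O` differs from compound 1 as follows: cyclopropyl in place of difluoromethyl on a saturated chain carbon bound to an oxygen on an aromatic ring. Within the data shown here, no measured step bears directly on this change; compounds 2 and 3 carry cyclopropylmethoxy on another core, and their values only show that such compounds stay in the same broad range. Compound 4 is therefore expected to show no step beyond the scatter, a 1.1-fold lower number from compound 1 to compound 4 (0.04 log units; within the scatter). The estimate for compound 4 is 1.1 L/kg, with a range from 0.6 L/kg to 2 L/kg.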

Compound 4, volume of distribution at steady state: 1 L/kg
Estimate against measurement, compound 4: 1.1-fold (0.04 log units) above, within the range that was stated.
By their numbers in this assay, from the lowest: compounds 3, 2, 4 and 1 (each within the scatter of the next, the first and the last beyond it).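

On the core of compound 1, cyclopropyl in place of difluoromethyl on a saturated chain carbon bound to an oxygen on an aromatic ring gives a 1.2-fold lower number from compound 1 to compound 4 (0.08 log units; within the scatter) in this assay. Going by these compounds alone, this is the first direct reading of this change at this place, and the two groups are not told apart by this read-out. No measurement shown offers a cause for this result.

Still open, from the compounds shown here alone, is how an amine or a longer chain at this place would read in this assay. Also open, going by these compounds, is whether the same change reads alike on the core of compound 2, where cyclopropylmethoxy has no 2,2-difluoroethoxy partner.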